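Exchanging the group on the saturated ring carbon

A few compounds are considered here, and "the series" means these few. Any claim that something is new, unique, unknown or untested is made for them only; others in the source may bear on it.

Within the data shown here, in an ADME assay on MT4 cells (Homo sapiens) for cytotoxicity, read by MTT assay, with a stated time of 96 h (on this read-out higher numbers stand for lower toxicity in this test and lower numbers for higher toxicity in this test), compound 1 `Cc1cccc(C2CC(c3ccc(Oc4ccccc4)cc3)=NN2c2ccc(S(N)(=O)=O)cc2)c1` gives 35000 nM and compound 2 `NS(=O)(=O)c1ccc(N2N=C(c3ccc(Oc4ccccc4)cc3)CC2c2ccc(F)cc2)cc1` gives 33000 nM, so compound 2 stands within the scatter of the only other measured value. Compound 3 `Cc1ccccc1C1CC(c2ccc(Oc3ccccc3)cc2)=NN1c1ccc(S(N)(=O)=O)cc1` carries 2-methylphenyl in place of 4-fluorophenyl on a saturated ring carbon. Among the measured compounds shown here, the one measured step bearing on this, a 1.1-fold lower number from compound 1 to compound 2 (0.03 log units; within the scatter), is an exchange on the same carbon and stays within the scatter. No step beyond the scatter is therefore expected in this assay, and the estimated result is a 1.0-fold higher number from compound 2 to compound 3 (0.01 log units; within the scatter). Compound 3 is expected at 34000 nM, with an estimated range of 18000 nM to 65000 nM.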

Compound 3, half-maximal cytotoxic concentration: 36000 nM
The estimate for compound 3 lay 1.1-fold (0.02 log units) below the measured number; low and high end bracket the measured number.
By their numbers in this assay, from the lowest: compounds 2, 1 and 3 (each within the scatter of the next).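

Two steps in this assay now reach 2-methylphenyl on the saturated ring carbon: a 1.1-fold higher number from compound 2 to compound 3 (0.04 log units; within the scatter) and a 1.0-fold higher number from compound 1 to compound 3 (0.01 log units; within the scatter) in an exchange of 3-methylphenyl for its 2-methyl isomer. Among these compounds, both lie within the scatter, so 4-fluorophenyl, 3-methylphenyl and 2-methylphenyl read alike at this carbon, and the place of the methyl group on the phenyl ring adds no step here.

Open, going by these compounds, is whether an amine, a carboxylic acid or a longer chain on this carbon would give a step beyond the scatter. No measurement at hand offers an explanation for these readings.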